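The source may hold more compounds than are shown below. What is called first, only, known or untested is meant among the compounds shown, and "the series" means these compounds.

Of the compounds shown here, three of one shared core have been measured in a functional assay on PC-3 cells (Homo sapiens) for inhibition, read by MTT assay, with a stated time of 48 h; on this read-out higher numbers stand for weaker inhibition and lower numbers for stronger inhibition. Compound 1 `C=C1CC[C@@H]2[C@](C)(CO)[C@H](O)CC[C@@]2(C)[C@@H]1CC(Sc1ccc([N+](=O)[O-])cc1)C1=CCOC1=O` gives 17000 nM. Compound 2 `C=C1CC[C@@H]2[C@](C)(CO)[C@H](O)CC[C@@]2(C)[C@@H]1CC(Sc1ccc(OC)cc1)C1=CCOC1=O` gives 15000 nM. Compound 3 `C=C1CC[C@@H]2[C@](C)(CO)[C@H](O)CC[C@@]2(C)[C@@H]1C/C=C1/C(=O)OC[C@H]1OC(=O)CCCSc1ccc(OC)cc1` gives 19000 nM. The change from compound 2 to compound 1 is nitro in place of methoxy on an aromatic carbon and produced a 1.1-fold higher number from compound 2 to compound 1 (0.05 log units; within the scatter). Compound 3 and compound 2 differ in more than this, and the difference between their two cores is not broken down here; their two values lie within the scatter of each other.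

Compound 4 `C=C1CC[C@@H]2[C@](C)(CO)[C@H](O)CC[C@@]2(C)[C@@H]1C/C=C1/C(=O)OC[C@H]1OC(=O)CCCSc1ccc([N+](=O)[O-])cc1` has not yet been measured in this assay. It relates to compound 3 as compound 1 relates to compound 2: the change is nitro in place of methoxy on an aromatic carbon, placed as the earlier one was, so it counts as the same change. For the measured compounds named here, the one earlier instance rests on a single pair, whose step from compound 2 to compound 1 was a 1.1-fold higher number from compound 2 to compound 1 (0.05 log units; within the scatter). On that basis, the step from compound 3 to compound 4 is expected to be a 1.1-fold higher number from compound 3 to compound 4 (0.02 log units; within the scatter), of similar size. Compound 4 is therefore estimated at 20000 nM, with a range of 10000 nM to 40000 nM, before its measurement is known.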

Compound 4, half-maximal inhibitory concentration: 17000 nM
Beside the measured number, compound 4's estimate is 1.2-fold (0.07 log units) above it; the range from low to high includes it.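

In this assay, nitro in place of methoxy on an aromatic carbon gave a 1.1-fold lower number from compound 3 to compound 4 (0.05 log units; within the scatter). Set beside the earlier instance of this change on the other core, the two steps do not differ: the same change on two cores in this assay, a 1.1-fold higher number (0.05 log units; within the scatter) from compound 2 to compound 1 and a 1.1-fold lower number (0.05 log units; within the scatter) from compound 3 to compound 4, 1.3-fold (0.10 log units) apart, within the scatter of two such steps. In these two pairs, the change leaves the read-out within the scatter on either core, but this shows only that an absence of a clear effect recurs, in one cell assay and at this level of inhibition, and two pairs cannot show whether a change that did move the number would carry from one core to the other.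

The compounds shown leave open whether another group in the place of the nitro or methoxy, such as an amine or a carboxylic acid, would move the number beyond the scatter on either core. Also open, as far as these compounds go, is what a longer chain carrying the (4-methoxyphenyl)sulfanyl group would do on the core of compound 3.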